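A Halogen Swap at the Far End of the Phenoxy Tail

The source may hold more compounds than are shown below. What is called first, only, known or untested is meant among the compounds shown, and "the series" means these compounds.

Compound 1 `NC1=NC2(CCOCC2)N(OCCCOc2ccc(F)cc2)C(N)=N1`: > 90%
Compound 2 `NC1=NC2(CCSCC2)N(OCCCOc2cc(Cl)c(Cl)cc2Cl)C(N)=N1`: 84.4%
Compound 3 `NC1=NC2(CCSCC2)N(OCCCOc2ccccc2Br)C(N)=N1`: 88.7%

Three compounds sharing the same core, each carrying a phenoxy tail with different halogen substitution, were tested in an assay on isolated protein for inhibition of Dihydrofolate reductase (Homo sapiens), read by spectrophotometry, using NADPH, with stated times of 5 s and 6 min, tested at 5 uM; on this read-out higher numbers stand for a stronger effect at the one concentration tested and lower numbers for a weaker effect. Compound 1 gives > 90%, which is a limit of the assay rather than a number. Compound 2 gives 84.4% and compound 3 gives 88.7%. The one step among these compounds that changes a single feature, a number 4.3 percentage points higher from compound 2 to compound 3 (within the scatter), swaps the halogen pattern on the aromatic ring and stays within the scatter.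

Compound 4 `NC1=NC2(CCOCC2)N(OCCCOc2ccc(Br)cc2)C(N)=N1` differs from compound 1 by bromo in place of fluoro on an aromatic carbon. This is again a halogen exchange on the same aromatic ring, so the step from compound 2 to compound 3 is the relevant precedent, and it was small. No step beyond the scatter is therefore expected in this assay. Because compound 1 already stands at the limit of > 90% in this assay, at which 1 of the 3 values shown sits, compound 4 is expected to sit at or near that limit as well. Compound 4 is estimated at 92%, with a range from 84% to 98%. The step that the limit leaves unreadable from compound 1 to compound 4 is expected to be within the scatter.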

Compound 4, a percentage reported as inhibition, at one concentration (the size of the read-out at that concentration, not a potency): > 90%
Compound 4: a limit, no number (the forecaster's own chance of this, stated with the estimate: 60%); the middle value does not contradict the limit.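

In this assay compound 4 gives > 90%, which is a limit and not a number. Compound 1 gives > 90%, also a limit, so no step can be read between compound 1 and compound 4. The compounds shown leave open whether bromo in place of fluoro changes the effect in this assay at all.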